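Three Thiazole-Oxadiazoles Without Toxicity Signal, and a Benzyl Analogue

The source may hold more compounds than are shown below. What is called first, only, known or untested is meant among the compounds shown, and "the series" means these compounds.

Compound 1, `Cc1nc(-c2cccnc2)sc1-c1nnc(-c2ccncc2)o1`, in an ADME assay on HeLa cells (Homo sapiens) for cytotoxicity, read by MTT assay (on this read-out higher numbers stand for lower toxicity in this test and lower numbers for higher toxicity in this test), gives > 100 ug/mL, a limit of the test.
Compound 2, `Cc1nc(-c2cccnc2)sc1-c1nnc(-c2cccnc2)o1`, in this assay gives > 100 ug/mL, again a limit.
Compound 3, `Cc1ccccc1-c1nnc(-c2sc(-c3cccnc3)nc2C)o1`, in this assay gives > 100 ug/mL, once more a limit.

Among the compounds with values here, all three measured compounds sit at the limit of > 100 ug/mL in this assay, at which 3 of the 3 values shown sit, so none of the measured steps can be read: a step that the two limits leave unreadable from compound 1 to compound 2, a step that the two limits leave unreadable from compound 1 to compound 3 and a step that the two limits leave unreadable from compound 2 to compound 3 are all unreadable in size. Compound 3 therefore stands only at a limit, not at a number, and it is indistinguishable in this assay from compounds 1 and 2.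

Compound 4, `Cc1nc(-c2cccnc2)sc1-c1nnc(Cc2ccccc2)o1`, is not yet measured. The change from compound 3 is benzyl in place of 2-methylphenyl on an aromatic carbon. Within the data shown here, no measured step bears on this change, since every step among compounds 1, 2 and 3 is hidden by the limit; the only guide is that all three measured values sit at the limit of > 100 ug/mL in this assay, at which 3 of the 3 values shown sit. Compound 4 is therefore expected to show a step that the limit leaves unreadable from compound 3 to compound 4, that is, no readable shift. The estimate for compound 4 in this assay is 120 ug/mL, within 60 ug/mL to 300 ug/mL, with the result most likely reported again as a limit.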

Compound 4, half-maximal cytotoxic concentration: > 100 ug/mL
Compound 4 was reported as a limit; the forecaster's own chance of this, stated with the estimate: 80%; the middle value does not contradict the limit.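

Compound 4, like compounds 1, 2 and 3, stands only at a limit, so none of the steps to compound 4 can be read: the limit of > 100 ug/mL in this assay, at which 4 of the 4 values shown sit.

The compounds shown leave open whether these four differ at all in this assay, and at what concentration each would become toxic to the cells.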